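Bromo for nitro: the next step in the series

A few compounds are considered here, and "the series" means these few. Any claim that something is new, unique, unknown or untested is made for them only; others in the source may bear on it.

Measured so far:
compound 1 `Cc1ccc(-n2c(Nc3nc(-c4ccc([N+](=O)[O-])cc4)cs3)n[nH]c2=S)cc1` — in a functional assay on the whole organism (strain Swiss albino) for inhibition, with Mus musculus as the target, with a stated time of 4 h (a lower number here means that less compound is needed, a higher number that more compound is needed for the effect), compound 1 gives 300 mg/kg
compound 2 `COc1ccccc1-n1c(Nc2nc(-c3ccc([N+](=O)[O-])cc3)cs2)n[nH]c1=S` — in this assay compound 2 gives 100 mg/kg

Compound 2 has the lowest of the two numbers; its nearest neighbour is compound 1, with a 3.0-fold lower number from compound 1 to compound 2 (0.48 log units; beyond the scatter).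

Compound 3 `COc1ccccc1-n1c(Nc2nc(-c3ccc(Br)cc3)cs2)n[nH]c1=S` differs from compound 2 by bromo in place of nitro on an aromatic carbon. Going by the values given here, no measured step touches this aromatic carbon; the single known step changed only the group on the aromatic nitrogen and was modest. No step beyond the scatter is therefore expected in this assay, with a slight lean toward a higher number: a 1.5-fold higher number from compound 2 to compound 3 (0.18 log units; within the scatter). Compound 3 is estimated at 150 mg/kg, range 75 mg/kg to 450 mg/kg.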

Compound 3, minimum effective dose: 300 mg/kg
Compound 3: the middle estimate sits 2.0-fold (0.30 log units) below what was measured, and the stated range covers the measured number.
By their numbers in this assay, from the lowest: compound 2; then compounds 1 and 3 (each within the scatter of the next).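

The aromatic carbon of the 4-nitrophenyl group is not a silent position: in this assay bromo in place of nitro gives a 3.0-fold higher number from compound 2 to compound 3 (0.48 log units; beyond the scatter) and so the result depends on this group as well as on the group on the aromatic nitrogen. The step is the same size as a 3.0-fold lower number from compound 1 to compound 2 (0.48 log units; beyond the scatter) in the earlier pair. Nothing available bears on the reason for the change.

On these data alone, how an amine or a carboxylic acid on this aromatic carbon would read remains open. Also open, as far as these compounds go, is whether the step from 4-nitrophenyl to 4-bromophenyl keeps its size with 4-methylphenyl on the aromatic nitrogen.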